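A Shorter Amide Group on the Shared Core

This account rests on a few compounds, and the source may have more. Where it says the series, first, only, none or still open, it means among the compounds named here.

Measured so far:
- compound 1 `CCCNC(=O)C1=CC(C)(C)Oc2ccc([N+](=O)[O-])cc21` gives 5.75 nM
- compound 2 `CCCCNC(=O)C1=CC(C)(C)Oc2ccc([N+](=O)[O-])cc21` gives 21.9 nM

Going by the values given here, in a functional assay (muscle tissue) with Rattus norvegicus as the target (on this read-out lower numbers stand for an effect already at smaller amounts and higher numbers for an effect only at larger amounts of compound), compound 2 gives 21.9 nM and so holds the highest of the two numbers so far. Compound 3 `CC1(C)C=C(C(=O)NC2CC2)c2cc([N+](=O)[O-])ccc2O1` keeps the shared core and changes in one place only, with cyclopropyl in place of butyl on an amide-type nitrogen as the whole difference. Among the compounds with values here, the one measured step that bears on this is a 3.8-fold higher number from compound 1 to compound 2 (0.58 log units; beyond the scatter) and it is modest but beyond the scatter. That step went with a methyl in place of hydrogen on a saturated chain carbon. Compound 3 moves back toward fewer carbons on the amide-type nitrogen, so a lower number is expected in this assay by about the size of that step or somewhat less. Within the data shown here, no compound with a ring on this nitrogen has a measured value yet, so this guide is loose. The expected change is a 2.2-fold lower number from compound 2 to compound 3 (0.34 log units; beyond the scatter) in this estimate. Compound 3 is estimated at 10 nM with an expected range from 3 nM to 33 nM in repeated measurements.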

Compound 3, half-maximal effective concentration: 32.4 nM
Compound 3: middle estimate off by 3.2-fold (0.51 log units), on the low side, and the stated range covers the measured number.
By their numbers in this assay, from the lowest: compound 1; then compounds 2 and 3 (each within the scatter of the next).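

In this assay, cyclopropyl in place of butyl on the amide-type nitrogen gives a 1.5-fold higher number from compound 2 to compound 3 (0.17 log units; within the scatter) and so leaves compound 3 and compound 2 indistinguishable on this read-out, even though the new group has 3 heavy atoms in place of 4 and brings a ring. Cyclopropyl in place of propyl at the same nitrogen gives a 5.6-fold higher number from compound 1 to compound 3 (0.75 log units; beyond the scatter) and this modest step lies beyond the scatter, so a shorter group than butyl does not by itself restore the low number of compound 1, and a small ring and a straight chain cannot be treated as interchangeable at this position. Nothing in the available evidence accounts for this gap between the ring and the chain.

The compounds shown leave open whether ethyl, a still shorter chain, would give a lower or higher number than propyl, and whether a branched group such as isopropyl would read more like the chain or the ring. They also leave open how a larger ring such as cyclobutyl, or a chain ending in an amine, would behave on this nitrogen.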